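Adding a Second Trifluoromethyl to Compound 2

A few compounds are considered here, and "the series" means these few. Any claim that something is new, unique, unknown or untested is made for them only; others in the source may bear on it.

Measured so far:
Compound 1 `Nc1cccc2c(-c3cccc(NC(=O)c4cc(C(F)(F)F)cc(C(F)(F)F)c4)c3)ccnc12`: 3400 nM
Compound 2 `CC(=O)Nc1cccc2c(-c3cccc(NC(=O)c4cccc(C(F)(F)F)c4)c3)ccnc12`: 8000 nM
Compound 3 `CC(=O)Nc1cccc2c(-c3cccc(NC(=O)c4ccc(F)c(C(F)(F)F)c4)c3)ccnc12`: 6800 nM

In a functional assay on A375P cells (Homo sapiens) for antiproliferative activity, read by MTT assay, with a stated time of 48 h (a lower number here means a stronger inhibitor, a higher number a weaker inhibitor), compound 2 gives the highest of the three numbers; compound 3 sits nearest, compound 1 furthest. Compound 4 `CC(=O)Nc1cccc2c(-c3cccc(NC(=O)c4cc(C(F)(F)F)cc(C(F)(F)F)c4)c3)ccnc12` differs from compound 2 by trifluoromethyl in place of hydrogen on an aromatic carbon. Going by the values given here, the one measured step, a 1.2-fold lower number from compound 2 to compound 3 (0.07 log units; within the scatter), adds a fluorine rather than a trifluoromethyl group and says little about this change. Compound 1, which carries the same two trifluoromethyl groups as compound 4, shows a lower number than compound 2, but the two also differ elsewhere. Compound 4 is therefore expected to show a modest improvement, a 1.8-fold lower number from compound 2 to compound 4 (0.25 log units; within the scatter). The estimate for compound 4 in this assay is 4500 nM, with a range from 2000 nM to 10000 nM.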

Compound 4, half-maximal inhibitory concentration: 1000 nM
Estimate against measurement, compound 4: 4.5-fold (0.65 log units) above, and the stated range ends above it.
By their numbers in this assay, from the lowest: compound 4; then compounds 1, 3 and 2 (each within the scatter of the next, the first and the last beyond it).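

In this assay, trifluoromethyl in place of hydrogen on this aromatic carbon gives an 8.0-fold lower number from compound 2 to compound 4 (0.90 log units; beyond the scatter) and so moves the number well beyond the scatter. The acetyl on the nitrogen also matters with both trifluoromethyl groups in place, giving a 3.4-fold lower number from compound 1 to compound 4 (0.53 log units; beyond the scatter) as its step. Nothing measured here explains either step.

Going by these compounds, whether a chlorine or a nitrile on this aromatic carbon would give a similar step remains open. So does whether the acetyl step would hold with only one trifluoromethyl group present.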